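This account rests on a few compounds, and the source may have more. Where it says the series, first, only, none or still open, it means among the compounds named here.

Measured in a physicochemical assay for lipophilicity, using the shake flask method, in phosphate buffer, measured as octanol-water partition, with a stated time of 30 min, at pH 7.4; a lower number here means a more polar compound, a higher number a more lipophilic compound:
- compound 1 `Cc1nccn1-c1cnc(NCc2c(F)ccc3c2CCO3)c2cn[nH]c(=O)c12`: 2.1
- compound 2 `Cn1nccc1-c1cnc(NCc2c(F)ccc3c2CCO3)c2cn[nH]c(=O)c12`: 2.6
- compound 3 `Cc1ncc(-c2cnc(NCc3c(F)ccc4c3CCO4)c3cn[nH]c(=O)c23)n1C`: 1.9

Compound 3 cannot be told apart from compound 1 in this assay, as the record shows a number 0.20 log units lower from compound 1 to compound 3 (within the scatter). Compound 2 stands clear of it, with a number 0.70 log units lower from compound 2 to compound 3 (beyond the scatter).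

Compound 4 `CNC(=O)c1ncc(-c2cnc(NCc3c(F)ccc4c3CCO4)c3cn[nH]c(=O)c23)n1C` carries one change, methylcarbamoyl in place of methyl on an aromatic carbon. Within the data shown here, no measured pair makes this change. The nearest evidence comes from exchanges of the whole group on the core, such as a number 0.50 log units higher from compound 1 to compound 2 (beyond the scatter). These steps were modest at most and give no direction here, so no shift beyond the scatter is expected, though with wide uncertainty. The expected step is a number 0.10 log units higher from compound 3 to compound 4 (within the scatter). Compound 4 is estimated at 2, within an expected range of 1.5 to 2.6.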

Compound 4, distribution coefficient: 2.5
For compound 4 the middle estimate is 0.50 log units below the measured one, and the stated range covers the measured number.
By their numbers in this assay, from the lowest: compounds 3 and 1 (each within the scatter of the next); then compounds 4 and 2 (each within the scatter of the next).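

In this assay, methylcarbamoyl in place of methyl on the aromatic carbon between two ring nitrogen atoms gives a number 0.60 log units higher from compound 3 to compound 4 (beyond the scatter), the first step shown at this position, and the entering group holds one hydrogen-bond donor and one hydrogen-bond acceptor. The wider comparisons give a number 0.40 log units higher from compound 1 to compound 4 (beyond the scatter) and a number 0.10 log units lower from compound 2 to compound 4 (within the scatter), so the change carries the number clear of one earlier compound but not of the other. Nothing available accounts for the direction of the step.

The compounds shown leave open whether this step depends on the amide hydrogen or on the size of the group. A dimethylcarbamoyl group, a carboxylic acid or an aminomethyl group on this same carbon would show how far it holds.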